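The compounds below may be only part of what the source reports. "The series", "measured", "known", "first", "only" and "open" are said of these compounds alone.

Compound 1 `S=C(SCc1cn(Cc2ccccc2Cl)nn1)N1CCNCC1`: > 128000 nM
Compound 2 `S=C(SCc1cn(Cc2ccc(Cl)cc2)nn1)N1CCNCC1`: > 128000 nM

In a functional assay on ECa-109 cells (Homo sapiens) for inhibition, read by MTT assay, with a stated time of 72 h (a lower number here means a stronger inhibitor, a higher number a weaker inhibitor), compound 1 gives > 128000 nM, which is a limit of the assay and not a number. Compound 2 gives > 128000 nM, again a limit rather than a number. The step that the two limits leave unreadable from compound 1 to compound 2 cannot be sized, since both values sit at the limit of > 128000 nM in this assay, at which 2 of the 2 values shown sit. Compound 3 `O=C(OCc1ccccc1)N1CCN(C(=S)SCc2cn(Cc3ccccc3Cl)nn2)CC1` differs from compound 1 by benzyloxycarbonyl in place of hydrogen on an amine nitrogen in a ring. Within the data shown here, no measured step bears on this change, and the values shown are limits only, so no direction in this assay can be read from them. Compound 3 is expected to give about 128000 nM, between 40000 nM and 400000 nM, an estimated step of a number no higher from compound 1 to compound 3 (the limit leaves the size open).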

Compound 3, half-maximal inhibitory concentration: 56800 nM
The estimate for compound 3 lay 2.3-fold (0.35 log units) above the measured number; the measured number falls inside the stated range.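

In this assay, the ring amine nitrogen is the one place shown where a change yields a number and not a limit: benzyloxycarbonyl in place of hydrogen gives an at least 2.2-fold lower number from compound 1 to compound 3 (0.35 log units; beyond the scatter). The true size of this step stays open, since the value for compound 1 is only a limit of the assay: the limit of > 128000 nM in this assay, at which 2 of the 3 values shown sit.

The compounds shown leave open whether the carbonyl or the aromatic ring of benzyloxycarbonyl carries the step, and whether an acetyl or a plain benzyl group on the same nitrogen would do the same. They also leave open whether benzyloxycarbonyl would act alike on compound 2.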